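This account rests on a few compounds, and the source may have more. Where it says the series, first, only, none or still open, it means among the compounds named here.

Measured in a functional assay on M21 cells (Homo sapiens) for antiproliferative activity, read by sulforhodamine B assay, with a stated time of 48 h; on this read-out higher numbers stand for weaker inhibition and lower numbers for stronger inhibition:
compound 1 `O=C1NCCN1c1ccc(S(=O)(=O)Nc2ccc(F)cc2)cc1`: 230 nM
compound 2 `COc1ccc(NS(=O)(=O)c2ccc(N3CCNC3=O)cc2)cc1`: 580 nM
compound 3 `COc1ccccc1NS(=O)(=O)c1ccc(N2CCNC2=O)cc1`: 300 nM

Only one gap in this set lies beyond the scatter: a 2.5-fold higher number from compound 1 to compound 2 (0.40 log units; beyond the scatter). Compound 3 stands within the scatter of both other compounds: a 1.3-fold higher number from compound 1 to compound 3 (0.12 log units; within the scatter), and a 1.9-fold lower number from compound 2 to compound 3 (0.29 log units; within the scatter).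

Compound 4 `COc1cccc(NS(=O)(=O)c2ccc(N3CCNC3=O)cc2)c1` has not yet been measured in this assay. The change is 3-methoxyphenyl in place of 2-methoxyphenyl on a sulfonamide nitrogen, with 3-methoxyphenyl in place of 2-methoxyphenyl on a sulfonamide nitrogen. Going by the values given here, the one measured step that swaps one methoxyphenyl isomer for another is a 1.9-fold lower number from compound 2 to compound 3 (0.29 log units; within the scatter), and it is small. Among the compounds with values here, no measured compound carries the 3-methoxyphenyl group, so this rests on a single comparison. The working expectation is a value in the region of those two isomers. The estimated step is a 1.3-fold higher number from compound 3 to compound 4 (0.12 log units; within the scatter), so no change beyond the scatter is expected. Compound 4 is expected at 400 nM, with an estimated range of 190 nM to 850 nM.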

Compound 4, half-maximal inhibitory concentration: 65 nM
For compound 4 the middle estimate is 6.2-fold (0.79 log units) above the measured one; the whole stated range lies above it.
By their numbers in this assay, from the lowest: compound 4; then compounds 1, 3 and 2 (each within the scatter of the next, the first and the last beyond it).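

In this assay, going by these compounds alone, the isomer of the methoxyphenyl group on the sulfonamide nitrogen matters more than the first pair of isomers showed: compound 2 and compound 3 stand within the scatter of each other, yet 3-methoxyphenyl gives a 4.6-fold lower number from compound 3 to compound 4 (0.66 log units; beyond the scatter) and an 8.9-fold lower number from compound 2 to compound 4 (0.95 log units; beyond the scatter). The same group also improves on 4-fluorophenyl, with a 3.5-fold lower number from compound 1 to compound 4 (0.55 log units; beyond the scatter), which makes compound 4 the most potent of the four. Nothing at hand accounts for these steps.

The compounds shown leave open whether the gain belongs to the methoxy group itself or would also appear with another group on the phenyl ring, such as 3-hydroxyphenyl, 3-ethoxyphenyl or 3-fluorophenyl. On these data alone, it also remains open whether 3-aminophenyl or a dimethoxyphenyl group would keep this level of activity.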